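Cytotoxicity notes: chlorine pattern on the ethenyl aryl group

A few compounds are considered here, and "the series" means these few. Any claim that something is new, unique, unknown or untested is made for them only; others in the source may bear on it.

Measured so far in a functional assay on HeLa cells (Homo sapiens) for cytotoxicity, read by MTT assay, with a stated time of 72 h; a higher number here means a weaker inhibitor, a lower number a stronger inhibitor:
compound 1 `NS(=O)(=O)c1cc(-c2nnc(Cn3cc(-c4ccccc4)nn3)o2)c(Cl)cc1SCc1ccccc1`: 7000 nM
compound 2 `NS(=O)(=O)c1cc(-c2nnc(CNC(=O)c3ccccc3)o2)c(Cl)cc1SCc1ccccc1`: 105000 nM
compound 3 `NS(=O)(=O)c1cc(-c2nnc(/C=C/c3ccc(Cl)cc3)o2)c(Cl)cc1SCc1ccccc1`: 40000 nM

Compound 3 holds the second highest of the three numbers. Its nearest neighbour is compound 2, reached by a 2.6-fold lower number from compound 2 to compound 3 (0.42 log units; beyond the scatter); its furthest is compound 1, by a 5.7-fold higher number from compound 1 to compound 3 (0.76 log units; beyond the scatter). Both steps lie beyond the scatter, so compound 3 sits clearly between the two.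

Compound 4 `NS(=O)(=O)c1cc(-c2nnc(/C=C/c3c(Cl)cccc3Cl)o2)c(Cl)cc1SCc1ccccc1` is not yet measured. It differs from compound 3 by 2,6-dichlorophenyl in place of 4-chlorophenyl on a double-bonded chain carbon bound to a double-bonded chain carbon. Among the compounds with values here, every measured step so far exchanges the whole side chain on the shared core: a 15-fold higher number from compound 1 to compound 2 (1.18 log units; beyond the scatter), a 5.7-fold higher number from compound 1 to compound 3 (0.76 log units; beyond the scatter) and a 2.6-fold lower number from compound 2 to compound 3 (0.42 log units; beyond the scatter). Within the data shown here, none of them alters only the chlorine pattern on an aryl ring while keeping the ethenyl linkage, so no measured step bears directly on the change from compound 3 to compound 4. With the ethenyl aryl side chain retained and only the ring substitution moved, no step beyond the scatter is expected in this assay in either direction.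

Compound 4 is therefore estimated at 40000 nM, with a range of 15000 nM to 110000 nM, which means an expected step of no change at the digits printed from compound 3 to compound 4 (within the scatter).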

Compound 4, half-maximal inhibitory concentration: 12000 nM
Estimate against measurement, compound 4: 3.3-fold (0.52 log units) above, outside the stated range (below it).
By their numbers in this assay, from the lowest: compounds 1 and 4 (each within the scatter of the next); then compound 3; then compound 2.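

In this assay, within the data shown here, the change from 4-chlorophenyl to 2,6-dichlorophenyl is the first step that keeps the ethenyl linkage and alters only the aryl ring, and it moves the number beyond the scatter (a 3.3-fold lower number from compound 3 to compound 4 (0.52 log units; beyond the scatter)), so the chlorine pattern on this ring matters in its own right. The ethenyl side chain therefore does not fix the number by itself: 2-(2,6-dichlorophenyl)ethenyl stands well apart from benzamidomethyl (an 8.8-fold lower number from compound 2 to compound 4 (0.94 log units; beyond the scatter)) and is within the scatter of (4-phenyl-1H-1,2,3-triazol-1-yl)methyl (a 1.7-fold higher number from compound 1 to compound 4 (0.23 log units; within the scatter)), a level that 2-(4-chlorophenyl)ethenyl did not reach. No measurement on hand accounts for the effect of the chlorine change.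

With only these two ring patterns, the gain of a second chlorine atom cannot be separated from the loss of the 4-chloro arrangement. Also open, going by these compounds, is how the number responds on this ethenyl side chain to an unsubstituted phenyl ring, or to a ring carrying a methoxy group or an amine in place of chlorine.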